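A few compounds are considered here, and "the series" means these few. Any claim that something is new, unique, unknown or untested is made for them only; others in the source may bear on it.

Compound 1 `CC(=O)OC[C@H]1O[C@@H](n2cc(CCl)nn2)[C@H](OC(C)=O)[C@@H](OC(C)=O)[C@@H]1OC(C)=O` carries a chloromethyl-substituted triazole on the peracetylated sugar core. Going by the values given here, in a functional assay on HeLa cells (Homo sapiens), read by colorimetric assay, with a stated time of 72 h (a higher number here means that more compound is needed for the effect, a lower number that less compound is needed), compound 1 gives 37 ug/mL, and this is the only actual number recorded among the two measured compounds. Compound 2 `CC(=O)N[C@@H]1[C@@H](OC(C)=O)[C@H](OC(C)=O)[C@@H](COC(C)=O)O[C@H]1n1nncc1CO` differs in its sugar and bears a hydroxymethyl on the triazole. In this assay compound 2 reaches only a limit of the assay, > 100 ug/mL. So compound 1 stands alone as the measured point, while the other entry sits at the limit of > 100 ug/mL in this assay, at which 1 of the 2 values shown sits. Among the compounds with values here, no step between two measured compounds is available, so nothing about the size of such steps can be taken from the data.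

Compound 3 `CC(=O)OC[C@H]1O[C@@H](n2nnc(CBr)c2CBr)[C@H](OC(C)=O)[C@@H](OC(C)=O)[C@@H]1OC(C)=O` is the unmeasured analogue. Relative to compound 1 the change is 4,5-bis(bromomethyl)-1H-1,2,3-triazol-1-yl in place of 4-(chloromethyl)-1H-1,2,3-triazol-1-yl on a saturated ring carbon. Within the data shown here, with only a single number as anchor, the step is expected to be moderate and toward a lower concentration, though a result within the scatter of compound 1 would not surprise. Compound 3 is expected to give about 20 ug/mL in this assay, within 5 ug/mL to 60 ug/mL, a step of a 1.9-fold lower number from compound 1 to compound 3 (0.27 log units; within the scatter).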

Compound 3, concentration for half-maximal effect: 3 ug/mL
Estimate against measurement, compound 3: 6.7-fold (0.82 log units) above; measured number outside the range, below it.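

In this assay the place on the saturated ring carbon next to the ring oxygen proves highly sensitive to what it carries: 4,5-bis(bromomethyl)-1H-1,2,3-triazol-1-yl in place of 4-(chloromethyl)-1H-1,2,3-triazol-1-yl gives a 12-fold lower number from compound 1 to compound 3 (1.09 log units; beyond the scatter) on an otherwise unchanged core. Going by these compounds alone, the earlier compounds offered no step at all, so this is the first evidence that a change at this place can move the number well beyond the usual scatter, and that it can move it toward less compound being needed. Nothing measured among the compounds shown accounts for the size of this step.

The step changes two things at once, the halogen and the number of halomethyl groups on the triazole, and the compounds shown do not separate the two, so it stays open how much each contributes. On these data alone, it also stays open whether a triazole with one bromomethyl group, or with an aminomethyl group or a longer bromoethyl chain in the same place, would keep the lower number, and whether the same change would act alike on the sugar of compound 2.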